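The source may report more compounds than this note shows. Statements on the series, on what has been measured and on what is new or still open speak of the compounds shown alone.

Measured compounds:
compound 1 `Nc1cc(-c2cc(Cl)cc3c2OC(C(=O)N2CCNCC2)C3)ccn1` — > 80000 nM
compound 2 `Cc1cc2nccc(-c3cc(Cl)cc4c3O[C@@H](C(=O)N3CCNCC3)C4)c2s1` — > 80000 nM
compound 3 `Cc1cc(Cl)cc(-c2ccnc3cc(CN4C(=O)C5C(C4=O)C5(C)C)sc23)c1O[C@@H]1CCNC[C@@H]1C` — > 10000 nM

All three were tested in an assay on Sf21 cells for inhibition of ubiquitin carboxyl-terminal hydrolase 1 (Homo sapiens), read by fluorescence; on this read-out lower numbers stand for stronger inhibition and higher numbers for weaker inhibition. None of them gives a number: each result is a limit of the assay. Two values sit at the limit of > 80000 nM in this assay, at which 2 of the 3 values shown sit, and one sits at the limit of > 10000 nM in this assay, at which 1 of the 3 values shown sits. Compound 2 is therefore not placed anywhere on a scale of strength; its result, > 80000 nM, is a limit, meaning the assay could not measure inhibition within its range. Among the three compounds, no pair differs in only one place, so no single-change step has been measured here and nothing shows how any one change moves the read-out.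

Compound 4 `O=C([C@H]1Cc2cc(Cl)cc(-c3ccnc4ccsc34)c2O1)N1CCNCC1` differs from compound 2 by one change: hydrogen in place of methyl on an aromatic carbon. The rest of the shared core, the chlorine and the amide-linked piperazine are kept.

Among the compounds with values here, with compound 2 at a limit and no measured step to lean on, the expectation for compound 4 is simply that it stays where compound 2 stands; the step of a number no higher from compound 2 to compound 4 (the limit leaves the size open) is expected to be none beyond the usual scatter. Compound 4 is estimated at 80000 nM, with a range from 30000 nM to 300000 nM, and most likely the assay will again report only a limit.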

Compound 4, half-maximal inhibitory concentration: > 40000 nM
Compound 4 gave a limit, no number (the forecaster's own chance of this, stated with the estimate: 85%); the middle value does not contradict the limit.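

In this assay, compound 2 and compound 4 both give limits rather than numbers, so the step that puts hydrogen in place of methyl on an aromatic carbon, next to the ring sulfur, cannot be read. The compounds shown leave open whether any change to them would give a measurable inhibition.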